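This account rests on a few compounds, and the source may have more. Where it says the series, first, only, none or still open, it means among the compounds named here.

Compound 1 `O=C1C(NC2CCCC2)=CC(=O)c2c1nc1n2[C@H]2OC[C@@H](O)[C@H]2OC1` gives > 16000 nM as a limit
Compound 2 `Cc1ccc(NC2=CC(=O)c3c(nc4n3[C@H]3OC[C@@H](O)[C@H]3OC4)C2=O)cc1` gives > 4000 nM as a limit

In a functional assay on MCF7 cells (Homo sapiens) for inhibition, read by sulforhodamine B assay (a higher number here means a weaker inhibitor, a lower number a stronger inhibitor), compound 2 stands at > 4000 nM as a limit, not a number. Compound 3 `O=C1C(N2CCCC2)=CC(=O)c2c1nc1n2[C@H]2OC[C@@H](O)[C@H]2OC1` comes next, with pyrrolidin-1-yl in place of (4-methylphenyl)amino on a double-bonded ring carbon in the change, that is, pyrrolidin-1-yl in place of (4-methylphenyl)amino on a double-bonded ring carbon. Within the data shown here, the only measured step that bears on this is a step that the two limits leave unreadable from compound 1 to compound 2 and its size cannot be read. It gives no ground for a large move in this assay so the estimated step that the limit leaves unreadable from compound 2 to compound 3 is small, with no firm direction. For compound 3 the expected value is 8000 nM and 2500 nM to 25000 nM is the estimated range.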

Compound 3, half-maximal inhibitory concentration: > 16000 nM
Compound 3 ended at the assay's limit (the forecaster's own chance of this, stated with the estimate: 70%); middle value at least 2.0-fold (0.30 log units) from the limit.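

Among these compounds, compound 1, compound 2 and compound 3 all stand as limits, not numbers, and no step among them can be read. The compounds shown leave open whether the group on the double-bonded ring carbon matters at all in this assay.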